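A Methyl in Place of a Methoxy

This account rests on a few compounds, and the source may have more. Where it says the series, first, only, none or still open, it means among the compounds named here.

In a functional assay on SK-OV-3 cells (Homo sapiens) for cytotoxicity (a higher number here means a weaker inhibitor, a lower number a stronger inhibitor), compound 1 `Cc1ccc2c(S)nc(-c3ccccc3)cc2c1` gives 34700 nM; 56200 nM (2 entries), while compound 2 `COc1ccc(-c2cc3cc(C)ccc3c(N3CCN(C)CC3)n2)cc1` gives 7940 nM, the lower number and so the stronger result. For the measured compounds named here, that is the only number for compound 2, as a further entry gave no single value. Compound 3 `Cc1ccc(-c2cc3cc(C)ccc3c(N3CCN(C)CC3)n2)cc1` differs from compound 2 in one place: methyl in place of methoxy on an aromatic carbon. Going by the values given here, no measured pair shows this swap, so no step beyond the scatter is expected in this assay, in either direction. The estimated step is a 1.0-fold higher number from compound 2 to compound 3 (0.00 log units; within the scatter). Compound 3 is expected at 8000 nM, with an estimated range of 3000 nM to 20000 nM.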

Compound 3, half-maximal inhibitory concentration: 7080 nM
Compound 3: the middle estimate sits 1.1-fold (0.05 log units) above what was measured, and the stated range covers the measured number.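

The swap of 4-methoxyphenyl to 4-methylphenyl gives a 1.1-fold lower number from compound 2 to compound 3 (0.05 log units; within the scatter) in this assay. This single pair shows that, at this position, methoxy with its hydrogen-bond acceptor can give way to methyl with no step beyond the scatter. Repeat readings of one compound lie further apart than this step: the several entries of compound 1 in this assay, 34700 nM; 56200 nM (2 entries)

The compounds shown leave open whether an amine, a carboxylic acid or a longer chain at this position would move the number beyond the scatter. From the compounds shown here alone, whether the same swap behaves alike on another core also stays open.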